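Swapping the Aryl Group on a Shared Core

A few compounds are considered here, and "the series" means these few. Any claim that something is new, unique, unknown or untested is made for them only; others in the source may bear on it.

Compound 1 `CC(=O)c1ccc(-c2cccc(NC(=O)CCc3ccc4c(c3)B(O)OC4)c2)cc1`: 19000 nM
Compound 2 `COc1cccc(-c2cccc(NC(=O)CCc3ccc4c(c3)COB4O)c2)c1`: 81000 nM
Compound 3 `COc1cc(OC)cc(-c2cccc(NC(=O)CCc3ccc4c(c3)COB4O)c2)c1`: 56000 nM

All three numbers come from a functional assay on HCT-116 cells (Homo sapiens) for antiproliferative activity, read by MTT assay, with a stated time of 72 h; on this read-out higher numbers stand for weaker inhibition and lower numbers for stronger inhibition. Compound 3 sits within the scatter of compound 2, and its number lies above that of compound 1 by more than the scatter.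

Compound 4 `CC(=O)c1ccc(-c2cccc(NC(=O)CCc3ccc4c(c3)COB4O)c2)cc1` has not yet been measured. It keeps the core of compound 3 but carries 4-acetylphenyl in place of 3,5-dimethoxyphenyl on an aromatic carbon.

For the measured compounds named here, only one measured step touches this group, a 1.4-fold lower number from compound 2 to compound 3 (0.16 log units; within the scatter). It adds a methoxy and stays within the scatter, but it says nothing direct about an acetyl group. Going by the values given here, the core of compound 4 is not identical to the one in the closest evidence, compound 1, which bears the same 4-acetylphenyl and gives 19000 nM. That value suggests a modest move towards a lower number in this assay, though the different core limits how far it can be trusted, and the move may not clear the scatter.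

The estimated change is a 1.6-fold lower number from compound 3 to compound 4 (0.20 log units; within the scatter).

For compound 4 the expected value is 35000 nM, with an estimated range of 15000 nM to 80000 nM.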

Compound 4, half-maximal inhibitory concentration: 63000 nM
Compound 4: middle estimate off by 1.8-fold (0.26 log units), on the low side; low and high end bracket the measured number.
By their numbers in this assay, from the lowest: compound 1; then compounds 3, 4 and 2 (each within the scatter of the next).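

With the shared core held fixed, replacing the aryl group does little in this assay: the change to 4-acetylphenyl gives a 1.1-fold higher number from compound 3 to compound 4 (0.05 log units; within the scatter) and a 1.3-fold lower number from compound 2 to compound 4 (0.11 log units; within the scatter), so 3,5-dimethoxyphenyl, 3-methoxyphenyl and 4-acetylphenyl cannot be told apart on this core. For the compounds shown here, the matched pair with the same 4-acetylphenyl group shows something the earlier compounds could not, since only the core group at the end of the saturated chain changes and the result is a 3.3-fold higher number from compound 1 to compound 4 (0.52 log units; beyond the scatter), a modest step but one beyond the scatter, which ties the lower number of compound 1 to its core and not to its acetyl group. No measurement at hand explains this gap between the two cores.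

Going by these compounds alone, the core of compound 1 appears here with only one aryl group, so it remains open whether 3-methoxyphenyl or 3,5-dimethoxyphenyl would keep the same advantage on that core. Also open, as far as these compounds go, is how an amine or a carboxylic acid on the aryl ring, or a longer chain leading to the core, would read in this assay.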